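This account rests on a few compounds, and the source may have more. Where it says the series, first, only, none or still open, it means among the compounds named here.

Among the measured compounds shown here, in a physicochemical assay for lipophilicity, read by HPLC, measured as chromatographic lipophilicity, at pH 7.4 (on this read-out higher numbers stand for higher lipophilicity and lower numbers for lower lipophilicity), three compounds built on a shared core have numbers so far: compound 1 (`COc1cccc(NC(=O)c2nnn(Cc3ccc(C#N)cc3)c2N)c1`) gives 2.3 and compound 2 (`COc1cccc(NC(=O)c2nnn(Cc3ccc(C(C)C)cc3)c2N)c1`) gives 3.4 while compound 3 (`COc1cccc(NC(=O)c2nnn(C(C)c3ccc(C(C)(C)C)cc3)c2N)c1`) gives 3.9 on the same scale. Compound 2 is thus the second highest of the three, nearer to compound 3 than to compound 1. Compound 4 (`COc1cccc(NC(=O)c2nnn(Cc3ccc(C4CC4)cc3)c2N)c1`) has not been measured yet. It differs from compound 2 in one place (cyclopropyl in place of isopropyl on an aromatic carbon), with cyclopropyl in place of isopropyl on an aromatic carbon. For the measured compounds named here, only one measured step touches that place: isopropyl in place of cyano gave a number 1.10 log units higher from compound 1 to compound 2 (beyond the scatter) and that step is large. The new change is narrower: both groups are made of carbon only, and the three-membered ring sets them apart. Going by the values given here, no measured compound carries cyclopropyl, so this comparison is only a rough guide. Any shift in this assay is expected to stay within the scatter, perhaps slightly downward, and the estimated step is a number 0.20 log units lower from compound 2 to compound 4 (within the scatter) on this scale. Compound 4 is estimated at 3.2 with 2.8 to 3.5 as the expected range.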

Compound 4, distribution coefficient: 3.2
Estimate against measurement, compound 4: no gap at the digits printed; measured number inside the range.
By their numbers in this assay, from the lowest: compound 1; then compounds 4 and 2 (each within the scatter of the next); then compound 3.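

In this assay, putting a ring at this position gives a number 0.20 log units lower from compound 2 to compound 4 (within the scatter), so isopropyl and cyclopropyl, each with three carbons and no hydrogen-bond donor or acceptor, cannot be told apart on this scale. Measured against the cyano group, cyclopropyl gives a number 0.90 log units higher from compound 1 to compound 4 (beyond the scatter), which means that compound 1 now stands clearly apart from two carbon-only groups rather than from isopropyl alone. No supporting data explain why the two carbon-only groups read alike. The compounds shown leave open how an amine, a carboxylic acid or a longer chain such as butyl would read at this position on the ring. As far as these compounds go, it is equally open whether a larger carbon ring such as cyclohexyl would stay as close to isopropyl as cyclopropyl does.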